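Pyrazine hydrazones on mouse macrophage cells: a hydroxy variant

The source may hold more compounds than are shown below. What is called first, only, known or untested is meant among the compounds shown, and "the series" means these compounds.

Measured so far:
compound 1 `O=C(N/N=C/c1ccccc1)c1cnccn1` — 75%
compound 2 `O=C(N/N=C/c1cccc(Cl)c1)c1cnccn1` — 100%

In an ADME assay on J774 cells (Mus musculus) for cytotoxicity, read by MTT assay, with a stated time of 48 h, tested at 100 ug/mL (a higher number here means a weaker effect of the compound at the concentration tested, a lower number a stronger effect), compound 1 gives 75%, the lowest of the two numbers shown. Among the compounds with values here, its nearest neighbour is compound 2, and compound 2 gives 100%; the single step known is a number 25 percentage points higher from compound 1 to compound 2 (beyond the scatter), brought about by chloro in place of hydrogen on an aromatic carbon.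

Compound 3 `O=C(N/N=C/c1ccc(O)cc1)c1cnccn1` has not been measured in this assay. It differs from compound 1 by hydroxy in place of hydrogen on an aromatic carbon. Within the data shown here, no measured step covers a hydroxy entering at this place; the only step available, from chloro, is modest, and a hydroxy is a different group. The account therefore expects at most a small shift in this assay, with no clear direction beyond the scatter, and the step is estimated as a number 5 percentage points higher from compound 1 to compound 3 (within the scatter). Compound 3 is expected to give about 80%, within a range of 55% to 100%.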

Compound 3, a percentage reported as activity, at one concentration (the size of the read-out at that concentration, not a potency): 81%
Compound 3: middle estimate off by 1 percentage points, on the low side; low and high end bracket the measured number.
By their numbers in this assay, from the lowest: compounds 1 and 3 (each within the scatter of the next); then compound 2.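

In this assay, hydroxy in place of hydrogen on an aromatic carbon, para to a large group, gives a number 6 percentage points higher from compound 1 to compound 3 (within the scatter), so compound 1 and compound 3 stand within the scatter of each other. Within the data shown here, the chloro change gave the only step known before, a number 25 percentage points higher from compound 1 to compound 2 (beyond the scatter), and it lies beyond the scatter; this result adds a substitution on the same aromatic ring that does not. No measured evidence bears on why the hydroxy step is this size.

The compounds shown leave open whether an amine or a carboxylic acid on this same carbon would also stay within the scatter of compound 1. They also leave open whether a hydroxy elsewhere on this ring would give a step of the same size.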